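A carboxylic acid at the end of the chain

This account rests on a few compounds, and the source may have more. Where it says the series, first, only, none or still open, it means among the compounds named here.

Compound 1, `O=C(O)CCCCCCCCCCCCCCCOc1ccc2c(=O)c(-c3ccc(O)cc3)coc2c1`, gives > 9000 nM in an assay (Cricetulus griseus) for inhibition of aldehyde dehydrogenase, mitochondrial (Homo sapiens); on this read-out lower numbers stand for stronger inhibition and higher numbers for weaker inhibition.
Compound 2, `CCOC(=O)COc1ccc2c(=O)c(-c3ccc(O)cc3)coc2c1`, gives 130 nM.
Compound 3, `C=CCCCCOc1ccc2c(=O)c(-c3ccc(O)cc3)coc2c1`, gives 150 nM.

The value of compound 1 is a limit of this assay, not a number (the limit of > 9000 nM in this assay, at which 1 of the 3 values shown sits). Of the two numbers shown, compound 3 sits highest; its nearest neighbour is compound 2, and the step of a 1.2-fold higher number from compound 2 to compound 3 (0.06 log units; within the scatter) lies within the scatter. Compound 4, `O=C(O)CCCCCCOc1ccc2c(=O)c(-c3ccc(O)cc3)coc2c1`, has not been measured. It differs from compound 3 by 2-carboxyethyl in place of vinyl on a saturated chain carbon, four bonds along the chain from an oxygen on an aromatic ring. Among the compounds with values here, the one measured step, a 1.2-fold higher number from compound 2 to compound 3 (0.06 log units; within the scatter), exchanged groups without adding an acid and stayed within the scatter, so it offers no direct guide. Compound 1, which carries the acid on a much longer chain, gives only a limit. A move toward weaker inhibition, a 5.3-fold higher number from compound 3 to compound 4 (0.73 log units; beyond the scatter), is therefore expected, and compound 4 is estimated at 800 nM, between 200 nM and 4000 nM.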

Compound 4, half-maximal inhibitory concentration: 50 nM
The estimate for compound 4 lay 16-fold (1.20 log units) above the measured number; measured number outside the range, below it.
By their numbers in this assay, from the lowest: compound 4; then compounds 2 and 3 (each within the scatter of the next). At a limit, above all of these: compound 1.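

In this assay, a carboxylic acid at the chain end is compatible with inhibition: 5-carboxypentyl gives a 3.0-fold lower number from compound 3 to compound 4 (0.48 log units; beyond the scatter) and a 2.6-fold lower number from compound 2 to compound 4 (0.41 log units; beyond the scatter). The acid-bearing chain of compound 1 is much longer, and shortening it gives an at least 180-fold lower number from compound 1 to compound 4 (2.25 log units; beyond the scatter), so the length of the chain carrying the acid matters greatly here. The value of compound 1 is a limit, not a number: the limit of > 9000 nM in this assay, at which 1 of the 4 values shown sits.

The compounds shown leave open whether a methyl ester or an amine at the end of this chain would match the acid. They also leave open how intermediate chain lengths would read.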